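A few compounds are considered here, and "the series" means these few. Any claim that something is new, unique, unknown or untested is made for them only; others in the source may bear on it.

Measured in a functional assay on HL-60 cells (Homo sapiens) for inhibition, read by MTT assay, with a stated time of 72 h; on this read-out lower numbers stand for stronger inhibition and higher numbers for weaker inhibition:

- compound 1 `C=C(C)c1ccc(N2CCN(C(=O)c3oc(C)nc3-c3ccccc3)CC2)cc1`: "not active" (no number reported)
- compound 2 `Cc1nc(-c2ccccc2)c(C(=O)N2CCN(c3ccccc3C(F)(F)F)CC2)o1`: 120 nM
- compound 3 `Cc1cc(C)cc(N2CCN(C(=O)c3oc(C)nc3-c3ccccc3)CC2)c1`: 34.5 nM

Of the two compounds with a number, compound 3 stands lowest at 34.5 nM, ahead of compound 2 at 120 nM. Compound 1 was reported without a number.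

The next compound, compound 4 `Cc1nc(-c2ccccc2)c(C(=O)N2CCN(c3ccc(Cl)c(Cl)c3)CC2)o1`, keeps the shared core of compound 3 and changes only the aromatic group on the piperazine-type ring nitrogen, described here as an amine nitrogen in a ring: 3,4-dichlorophenyl in place of 3,5-dimethylphenyl on an amine nitrogen in a ring. So 3,4-dichlorophenyl comes in place of 3,5-dimethylphenyl.

For the measured compounds named here, only one measured step bears on this place: a 3.5-fold lower number from compound 2 to compound 3 (0.54 log units; beyond the scatter), a modest step beyond the scatter. Compound 1 also differs from compound 3 only in this group, and it gave no number. Going by the values given here, no measured compound carries 3,4-dichlorophenyl, so the direction of the change is uncertain. Among the compounds with values here, both other groups at this place did worse than the one in compound 3, so a modest rise is the more likely outcome, of about the size of the one measured step. The expected change in this assay is a 1.9-fold higher number from compound 3 to compound 4 (0.28 log units; within the scatter). For compound 4 the estimated value is 65 nM, with an expected range from 20 nM to 210 nM.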

Compound 4, half-maximal inhibitory concentration: 124 nM
Compound 4: middle estimate off by 1.9-fold (0.28 log units), on the low side; the measured number falls inside the stated range.
By their numbers in this assay, from the lowest: compound 3; then compounds 2 and 4 (each within the scatter of the next).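

In this assay, the step of a 3.6-fold higher number from compound 3 to compound 4 (0.56 log units; beyond the scatter) shows that 3,5-dimethylphenyl is not simply interchangeable with another substituted phenyl at this place: the change of 3,5-dimethylphenyl to 3,4-dichlorophenyl on the amine nitrogen in the ring gives a modest rise beyond the scatter. The step of a 1.0-fold higher number from compound 2 to compound 4 (0.01 log units; within the scatter) lies within the scatter, so 3,4-dichlorophenyl and 2-(trifluoromethyl)phenyl cannot be told apart here, and of the three compounds with a number, only compound 3, with its 3,5-dimethylphenyl, stands apart. Steps to compound 1, which has no number, cannot be read, and nothing available accounts for the difference between these groups.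

Compound 3 and compound 4 differ both in the atoms on the phenyl ring and in their pattern, so the compounds shown do not separate methyl from chlorine or the one pattern from the other. Going by these compounds, how a plain phenyl, a methoxyphenyl or a pyridine ring on the same nitrogen would compare with 3,5-dimethylphenyl also stays open.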